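This account rests on a few compounds, and the source may have more. Where it says the series, first, only, none or still open, it means among the compounds named here.

Measured compounds:
compound 2 `Oc1cccc(-c2nc(N3CCCCC3)c3nc[nH]c3n2)c1` — > 80%
compound 1 `Cn1cnc2c(N3CCCCC3)nc(-c3cccc(O)c3O)nc21` — 26%

In an assay on cells for displacement of a labelled ligand from adenosine receptor A2b (Homo sapiens), read by scintillation counting and radioligand binding, with a stated time of 30 min, tested at 10 uM (on this read-out lower numbers stand for less inhibition and higher numbers for more inhibition at the one concentration tested (going by the name of the read-out)), compound 2 gives > 80%. From the compounds shown here alone, that value is a limit of the assay and not a number, so compound 2 sits at the limit of > 80% in this assay, at which 1 of the 2 values shown sits, and its true size is unknown. In this assay compound 1 gives 26%, a plain number.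

Compound 3 `Cn1cnc2c(N3CCCCC3)nc(-c3cccc(O)c3)nc21` is not yet measured. It differs from compound 2 in one place: methyl in place of hydrogen on an aromatic nitrogen. Within the data shown here, no step between two measured compounds that differ in one place is available, so the size of this change cannot be read from a measured pair. Compound 1 and compound 3 both carry the methyl on the ring nitrogen but also differ in a hydroxyl, so the values of compound 1 and compound 2 only show that one methylated compound sits low and one unmethylated compound sits at the limit.

Compound 3 is expected to give about 45%, within 15% to 78%. That estimate means a step of a number at least 35 percentage points lower from compound 2 to compound 3 (beyond the scatter) downward, beyond the scatter.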

Compound 3, a percentage reported as inhibition, at one concentration (the size of the read-out at that concentration, not a potency): 29.3%
The estimate for compound 3 lay 15.7 percentage points above the measured number; the measured number falls inside the stated range.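

In this assay, methyl in place of hydrogen on an aromatic nitrogen now has a measured step of its own: a number at least 50.7 percentage points lower from compound 2 to compound 3 (beyond the scatter). This step is a bound and not a size, since the value of compound 2 is a limit of the assay and not a number: the limit of > 80% in this assay, at which 1 of the 3 values shown sits. With the methyl present, hydrogen in place of hydroxy on an aromatic carbon gives a number 3.3 percentage points higher from compound 1 to compound 3 (within the scatter), so in this assay the nitrogen position carries the only change beyond the scatter among these steps.

From the compounds shown here alone, whether ethyl or a longer chain on this nitrogen would read like the methyl stays open, as does the effect of an amine in place of the hydroxy on the aromatic carbon. The effect of a second hydroxyl on the core without the methyl also cannot be read from these compounds.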